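Removing the Iodo Group from Compound 3

The source may report more compounds than this note shows. Statements on the series, on what has been measured and on what is new or still open speak of the compounds shown alone.

Measured in a functional assay on T98G cells (Homo sapiens) for cytotoxicity, read by MTT assay, with a stated time of 48 h; a higher number here means a weaker inhibitor, a lower number a stronger inhibitor:
Compound 1 `C/C(=N\NC(=S)Nc1cccc(F)c1)c1ccccn1`: 12 nM
Compound 2 `C/C(=N/NC(=S)Nc1ccccc1)c1ccccn1`: 6.81 nM
Compound 3 `C/C(=N/NC(=S)Nc1cccc(I)c1)c1ccccn1`: 61 nM

Among these three, compound 3 has the highest number, and its distance from each of the other two lies beyond the usual scatter. The next structure, compound 4 `C/C(=N/NC(=S)Nc1cccc(F)c1)c1ccccn1`, has fluoro in place of iodo on an aromatic carbon, meta to a large group: fluoro in place of iodo on an aromatic carbon.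

For the measured compounds named here, only one measured step involves this iodo group. It is a 9.0-fold higher number from compound 2 to compound 3 (0.95 log units; beyond the scatter), with iodo in place of hydrogen on an aromatic carbon. Going by the values given here, no measured pair exchanges iodo for fluoro directly, so this step is only a guide. Still, the number rose when iodo entered, and compound 1, which also carries a fluoro group, gives 12 nM. Both observations point to a clearly lower number once iodo leaves, on a scale somewhat smaller than the rise seen with iodo.

In this assay the expected step is a 5.1-fold lower number from compound 3 to compound 4 (0.71 log units; beyond the scatter). For compound 4 the estimated value is 12 nM, with an expected range of 4 nM to 35 nM.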

Compound 4, half-maximal inhibitory concentration: 12 nM
Beside the measured number, compound 4's estimate shows no gap at the digits printed; the range from low to high includes it.
By their numbers in this assay, from the lowest: compounds 2, 1 and 4 (each within the scatter of the next); then compound 3.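

In this assay, for the compounds shown here, replacing iodo with fluoro gives a 5.1-fold lower number from compound 3 to compound 4 (0.71 log units; beyond the scatter), the first direct exchange between these two groups on this aromatic carbon. Fluoro in place of hydrogen gives a 1.8-fold higher number from compound 2 to compound 4 (0.25 log units; within the scatter), so here compound 4 cannot be told apart from the unsubstituted compound 2, and among these three groups only iodo stands apart. Going by these compounds alone, the configuration of the double bond also shows no effect in this pair, which gives no change at the digits printed from compound 1 to compound 4 (within the scatter), and the comparison is a clean one: the fact that compounds 1 and 4 differ only in the configuration as drawn.

The compounds shown leave open whether chloro or bromo on this carbon would stay close to fluoro or move towards iodo, and how a methoxy group or an amine would behave there. They also leave open whether the double-bond configuration would matter with iodo in place of fluoro.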